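A few compounds are considered here, and "the series" means these few. Any claim that something is new, unique, unknown or untested is made for them only; others in the source may bear on it.

Measured so far in an assay on microsomes from liver for inhibition of 3-hydroxy-3-methylglutaryl-coenzyme A reductase (Rattus norvegicus); a higher number here means a weaker inhibitor, a lower number a stronger inhibitor:
compound 1, `O=C(O)C[C@H](O)C[C@H](O)CCn1c(C(F)(F)F)nc(-c2cccnc2)c1-c1ccc(F)cc1`: 66 nM
compound 2, `CC(C)c1nc(-c2cccc(S(C)(=O)=O)c2)c(-c2ccc(F)cc2)n1/C=C/[C@@H](O)C[C@@H](O)CC(=O)O`: 2 nM

Compound 2 stands at the lower of the two numbers; compound 1 gives 66 nM, a gap beyond the usual scatter. Compound 3, `CNc1cccc(-c2nc(C(C)C)n(/C=C/[C@@H](O)C[C@@H](O)CC(=O)O)c2-c2ccc(F)cc2)c1`, is not yet measured. It differs from compound 2 by methylamino in place of methylsulfonyl on an aromatic carbon. Going by the values given here, no measured pair shows this change, so the size of the step in this assay is unknown; a modest rise in the number is expected rather than none. For compound 3 the estimate is 6 nM, within 2 nM to 20 nM, an expected step of a 3.0-fold higher number from compound 2 to compound 3 (0.48 log units; beyond the scatter).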

Compound 3, half-maximal inhibitory concentration in the 3-hydroxy-3-methylglutaryl-coenzyme A reductase assay: 3 nM
Estimate against measurement, compound 3: 2.0-fold (0.30 log units) above, within the range that was stated.
By their numbers in the 3-hydroxy-3-methylglutaryl-coenzyme A reductase assay, from the lowest: compounds 2 and 3 (each within the scatter of the next); then compound 1.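

In the 3-hydroxy-3-methylglutaryl-coenzyme A reductase assay, methylamino in place of methylsulfonyl on this aromatic carbon gives a 1.5-fold higher number from compound 2 to compound 3 (0.18 log units; within the scatter), so this pair does not separate the two groups, although only methylamino carries a hydrogen-bond donor. In this pair, neither the sulfonyl oxygens nor the absence of a donor at this position is needed to hold the number. The same change does separate the pair in a physicochemical assay for lipophilicity (a higher number here means a more lipophilic compound, a lower number a more polar compound), where compound 2 gives -0.6 and compound 3 gives -0.05 as measured: the measured distribution coefficient of compound 2, -0.6, and of compound 3, -0.05, a number 0.55 log units higher (beyond the scatter)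

From the compounds shown here alone, whether this position accepts other groups, such as a carboxylic acid or a longer amine chain, remains open. One pair also cannot show whether the same exchange behaves alike on a different core.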